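Iodo for Isopropyl, Carried onto a Second Core

The source may hold more compounds than are shown below. What is called first, only, known or untested is meant among the compounds shown, and "the series" means these compounds.

In a functional assay on M21 cells (Homo sapiens) for antiproliferative activity, read by sulforhodamine B assay, with a stated time of 48 h (a higher number here means a weaker inhibitor, a lower number a stronger inhibitor), compound 1 `CCCCCC(=O)Nc1ccc(S(=O)(=O)Oc2ccccc2C(C)C)cc1` gives 6700 nM. Compound 2 `CCCCCC(=O)Nc1ccc(S(=O)(=O)Oc2ccccc2I)cc1` differs from it by iodo in place of isopropyl on an aromatic carbon, and in this assay compound 2 gives 11000 nM, a step of a 1.6-fold higher number from compound 1 to compound 2 (0.22 log units; within the scatter). Compound 3 `CC(C)C(=O)Nc1ccc(S(=O)(=O)Oc2ccccc2C(C)C)cc1` carries a different core, set apart from compound 1 by isopropyl in place of pentyl on a carbonyl carbon; in this assay compound 3 gives 11000 nM, a step of a 1.6-fold higher number from compound 1 to compound 3 (0.22 log units; within the scatter). Compound 4 `CC(C)C(=O)Nc1ccc(S(=O)(=O)Oc2ccccc2I)cc1` is still to be measured. Going by the values given here, it differs from compound 3 by iodo in place of isopropyl on an aromatic carbon, the same change as the one from compound 1 to compound 2, at a place described in the same words. Because a 1.6-fold higher number from compound 1 to compound 2 (0.22 log units; within the scatter) stayed within the scatter, the expected step is of similar size, a 1.5-fold higher number from compound 3 to compound 4 (0.16 log units; within the scatter). Compound 4 is estimated at 16000 nM, with a likely range from 8000 nM to 32000 nM.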

Compound 4, half-maximal inhibitory concentration: 13000 nM
The estimate for compound 4 lay 1.2-fold (0.09 log units) above the measured number, within the range that was stated.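

Iodo in place of isopropyl gives a 1.2-fold higher number from compound 3 to compound 4 (0.07 log units; within the scatter) in this assay and behaves alike on both cores: the same change on two cores in this assay, a 1.6-fold higher number (0.22 log units; within the scatter) from compound 1 to compound 2 and a 1.2-fold higher number (0.07 log units; within the scatter) from compound 3 to compound 4, 1.4-fold (0.14 log units) apart, within the scatter of two such steps. Isopropyl in place of pentyl gives a 1.2-fold higher number from compound 2 to compound 4 (0.07 log units; within the scatter) and also behaves alike on both cores: the same change on two cores in this assay, a 1.6-fold higher number (0.22 log units; within the scatter) from compound 1 to compound 3 and a 1.2-fold higher number (0.07 log units; within the scatter) from compound 2 to compound 4, 1.4-fold (0.14 log units) apart, within the scatter of two such steps. Going by these compounds alone, all of these steps lie within the scatter, so the agreement shows only that neither change produced a readable shift on either core, and it does not show that a real effect of either change carries from one core to another.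

The compounds shown leave open whether an amine or a carboxylic acid in place of the iodo, or a chain longer than pentyl on the carbonyl carbon, would give a step beyond the scatter. Such a step would offer a firmer test of carrying a change between cores.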